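Lengthening the Amine Chain on a Vasopressin Receptor Ligand

This account rests on a few compounds, and the source may have more. Where it says the series, first, only, none or still open, it means among the compounds named here.

Compound 1, `Cc1cc(N)ccc1C(=O)N1CCCCc2cc(Cl)ccc21`: 4.1 nM
Compound 2, `CNc1ccc(C(=O)N2CCCCc3ccccc32)c(Cl)c1`: 35 nM
Compound 3, `CCNc1ccc(C(=O)N2CCCCc3cc(Cl)ccc32)c(Cl)c1`: 5 nM

These three compounds were tested in an assay on HeLa cells for binding affinity to Vasopressin V2 receptor (Homo sapiens); a lower number here means a stronger inhibitor, a higher number a weaker inhibitor. Compound 2 gives the highest number of the three and is thus the weakest binder among them; compound 3 gives a clearly lower number and compound 1 lower still, both gaps lying beyond the usual scatter. Compound 4, `CCCCNc1ccc(C(=O)N2CCCCc3ccccc32)c(Cl)c1`, has not yet been measured. It differs from compound 2 by propyl in place of hydrogen on a saturated chain carbon bound to a nitrogen on an aromatic ring. Within the data shown here, no two measured compounds differ in only one place, so no measured step shows directly what a longer chain on that nitrogen does; compound 3 carries a longer chain than compound 2 but also differs elsewhere in its structure. On that basis the step of a 2.3-fold lower number from compound 2 to compound 4 (0.37 log units; beyond the scatter) is expected to be modest and toward a lower number, possibly within the scatter. Compound 4 is therefore expected to give about 15 nM, with a likely range from 4 nM to 60 nM.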

Compound 4, half-maximal inhibitory concentration: 22 nM
Beside the measured number, compound 4's estimate is 1.5-fold (0.17 log units) below it, and the stated range covers the measured number.
By their numbers in this assay, from the lowest: compounds 1 and 3 (each within the scatter of the next); then compounds 4 and 2 (each within the scatter of the next).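

Going from methylamino to butylamino in this assay gives a 1.6-fold lower number from compound 2 to compound 4 (0.20 log units; within the scatter) and is the first direct reading at this position. Compound 2 and compound 4 cannot be told apart, so adding propyl on this saturated chain carbon leaves binding in the same range, and this nitrogen can carry the longer chain. No available measurement bears on the reason for this result.

Still open, as far as these compounds go, is whether a chain longer than butyl, or one ending in an amine or a carboxylic acid, would fare the same. From the compounds shown here alone, it is also open whether this change would read alike on the core of compound 3.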